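Acyl swap on the shared core: compound 3 to compound 4

The source may report more compounds than this note shows. Statements on the series, on what has been measured and on what is new or still open speak of the compounds shown alone.

- compound 1 `COc1ccc(S(=O)(=O)N2CCc3cccc(NC(=O)c4cccs4)c32)cc1` 37 nM
- compound 2 `COc1ccc(S(=O)(=O)N2CCc3cccc(NC(=O)c4ccc([N+](=O)[O-])cc4)c32)cc1` 65 nM
- compound 3 `COc1ccc(S(=O)(=O)N2CCc3cccc(NC(C)=O)c32)cc1` 51 nM

In a functional assay on HT-29 cells (Homo sapiens) for cytotoxicity (a higher number here means a weaker inhibitor, a lower number a stronger inhibitor), compound 3 gives 51 nM and stands within the scatter of both compound 1 and compound 2, so the three values show no order. Compound 4 `COc1ccc(S(=O)(=O)N2CCc3cccc(NC(=O)c4ccco4)c32)cc1` has furan-2-yl in place of methyl on a carbonyl carbon. Among the measured compounds shown here, three measured steps bear on this: a 1.4-fold higher number from compound 1 to compound 3 (0.14 log units; within the scatter) for methyl in place of thiophen-2-yl, a 1.3-fold lower number from compound 2 to compound 3 (0.11 log units; within the scatter) for methyl in place of 4-nitrophenyl, and a 1.8-fold higher number from compound 1 to compound 2 (0.24 log units; within the scatter) for 4-nitrophenyl in place of thiophen-2-yl. All stay within the scatter, so no larger step is expected in this assay for this change. The expected step is a 1.1-fold lower number from compound 3 to compound 4 (0.05 log units; within the scatter) and lies within the scatter. Compound 4 is estimated at 45 nM (expected range 22 nM to 95 nM).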

Compound 4, half-maximal inhibitory concentration: 9.5 nM
The estimate for compound 4 lay 4.7-fold (0.68 log units) above the measured number; measured number outside the range, below it.
By their numbers in this assay, from the lowest: compound 4; then compounds 1, 3 and 2 (each within the scatter of the next).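

At this acyl position, this assay does respond to the group on the carbonyl carbon, which the three earlier compounds did not show: a 5.4-fold lower number from compound 3 to compound 4 (0.73 log units; beyond the scatter) and a 6.8-fold lower number from compound 2 to compound 4 (0.84 log units; beyond the scatter) and a 3.9-fold lower number from compound 1 to compound 4 (0.59 log units; beyond the scatter) all stand beyond the scatter. The last step replaces one five-membered aromatic ring with another, so having such a ring there does not by itself give the lower number.

As far as these compounds go, whether furan-2-yl is unique here stays open; a methyl-substituted furan or an aminoacetyl group would test this. Nothing available explains the drop.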